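Nitro for acetamido on the benzyl group of compound 3

The source may hold more compounds than are shown below. What is called first, only, known or untested is meant among the compounds shown, and "the series" means these compounds.

Measured compounds:
- compound 1, `O=c1c2ccccc2c(Nc2n[nH]c3ccccc23)nn1-c1ccccc1`: "not determined" (no result reported)
- compound 2, `COc1ccc(-n2nc(Nc3cc(C)[nH]n3)c3ccccc3c2=O)cc1`: 700 nM
- compound 3, `CC(=O)Nc1ccc(Cn2nc(Nc3cc(C)[nH]n3)c3ccccc3c2=O)cc1`: 4200 nM

In a functional assay on HCT-116 cells (Homo sapiens) for cytotoxicity, read by CellTiter-Glo, with a stated time of 5 days (on this read-out lower numbers stand for stronger inhibition and higher numbers for weaker inhibition), compound 3 gives 4200 nM, the highest of the two numbers available; compound 2 gives 700 nM, a gap beyond the scatter. In this assay compound 1 gives "not determined" (no result reported).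

Compound 4, `Cc1cc(Nc2nn(Cc3ccc([N+](=O)[O-])cc3)c(=O)c3ccccc23)n[nH]1`, differs from compound 3 in one place: nitro in place of acetamido on an aromatic carbon. Among the measured compounds shown here, no measured pair shows this exchange, so the step in this assay is expected to be small, in either direction or none beyond the scatter.

For compound 4 the expected step of a 1.4-fold lower number from compound 3 to compound 4 (0.15 log units; within the scatter) is within the scatter. Compound 4 is estimated at 3000 nM, between 1000 nM and 9000 nM.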

Compound 4, half-maximal inhibitory concentration: 1400 nM
Compound 4: the middle estimate sits 2.1-fold (0.33 log units) above what was measured, within the range that was stated.
By their numbers in this assay, from the lowest: compounds 2 and 4 (each within the scatter of the next); then compound 3.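

In this assay, among the compounds shown here, nitro in place of acetamido gives a 3.0-fold lower number from compound 3 to compound 4 (0.48 log units; beyond the scatter) at this aromatic carbon of the benzyl group, the first reading of a change at this position. The number here therefore moves with the group on this carbon, and the amide hydrogen of acetamido is not required for activity in this pair. Nothing measured bears on the cause of this step.

Open, from the compounds shown here alone, is where an amine or a carboxylic acid on this carbon would fall relative to compound 3 and compound 4. Also open, going by these compounds, is whether the unsubstituted benzyl group would match either compound.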